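The compounds below may be only part of what the source reports. "The series", "measured", "known", "first", "only" and "open" are said of these compounds alone.

The measured compounds:
Compound 1 `Brc1cccc(Nc2nc3ncccc3n2Cc2ccccc2)c1` gives 77700 nM in a functional assay on HCT-116 cells (Homo sapiens) for antiproliferative activity, read by MTT assay, with a stated time of 72 h; a higher number here means a weaker inhibitor of growth, a lower number a stronger inhibitor of growth.
Compound 2 `O=[N+]([O-])c1cccc(Nc2nc3ncccc3n2Cc2ccccc2)c1` gives 41700 nM in this assay.

Going by the values given here, compound 2 holds the lower of the two numbers so far recorded in this assay, but its only neighbour, compound 1, lies within the scatter of it, so the two cannot be ranked against each other. Among the compounds with values here, the single step measured, a 1.9-fold lower number from compound 1 to compound 2 (0.27 log units; within the scatter), is an exchange of one group for another on the aromatic ring and is itself within the scatter.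

Compound 3 `Cc1ccc(Nc2nc3ncccc3n2Cc2ccccc2)cc1[N+](=O)[O-]` has not yet been measured. It differs from compound 2 by methyl in place of hydrogen on an aromatic carbon. Within the data shown here, no measured step addresses an addition of this kind: the one step recorded swaps a bromo for a nitro rather than adding a methyl, and it was small in any case. On the numbers available there is therefore no ground to expect a shift beyond the scatter in either direction. For compound 3 the step is estimated as a 1.1-fold lower number from compound 2 to compound 3 (0.04 log units; within the scatter). Compound 3 is accordingly expected to give about 38000 nM in this assay, within a range of 13000 nM to 110000 nM.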

Compound 3, concentration for 50% growth inhibition: 40400 nM
Beside the measured number, compound 3's estimate is 1.1-fold (0.03 log units) below it; measured number inside the range.
By their numbers in this assay, from the lowest: compounds 3, 2 and 1 (each within the scatter of the next).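

In this assay, a methyl placed on an aromatic carbon, ortho to a nitro group and para to a large group, gives a 1.0-fold lower number from compound 2 to compound 3 (0.01 log units; within the scatter). The earlier compounds shown here showed only an exchange of bromo for nitro, whereas this step shows that an added carbon at this position, where a hydrogen stood before, brings no difference that can be read in this assay. No measurement at hand accounts for this result.

The compounds shown do not tell whether a larger group at this position, such as an ethyl chain, a methoxy group or an amine, would also stay within the scatter, or whether the methyl would do so with bromo in place of the nitro group. Nor do they tell whether a carboxylic acid or an amine in place of the nitro group would give a step beyond the scatter; every step shown so far stays within it.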